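The source may report more compounds than this note shows. Statements on the series, on what has been measured and on what is new or still open speak of the compounds shown alone.

Going by the values given here, in an ADME assay on Vero cells (Chlorocebus sabaeus) for cytotoxicity, read by neutral red uptake, tested at 197 ug/mL (on this read-out lower numbers stand for a stronger effect and higher numbers for a weaker effect at the one concentration tested), compound 1 `O=C1CSC(c2cccc(Cl)c2)N1CCN1CCCCC1` gives 77%, and compound 2 `O=C1CSC(c2ccc(F)cc2)N1CCN1CCCCC1` gives 73%; the two numbers lie within the scatter of one another, the only known step between them being a number 4 percentage points lower from compound 1 to compound 2 (within the scatter). Compound 3 `O=C1CSC(c2ccccc2Cl)N1CCN1CCCCC1` differs from compound 2 by 2-chlorophenyl in place of 4-fluorophenyl on a saturated ring carbon. Among the compounds with values here, the one measured step in this assay, itself an exchange of one halophenyl for another, stayed within the scatter, so the step from compound 2 to compound 3 is expected to be a number 2 percentage points higher from compound 2 to compound 3 (within the scatter), nothing beyond the scatter. Compound 3 is therefore estimated at 75%, within a range from 60% to 90%.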

Compound 3, a percentage reported as activity, at one concentration (the size of the read-out at that concentration, not a potency): 71%
Beside the measured number, compound 3's estimate is 4 percentage points above it; measured number inside the range.
By their numbers in this assay, from the lowest: compounds 3, 2 and 1 (each within the scatter of the next).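

In this assay the 2-chlorophenyl group on the saturated ring carbon gives a number 2 percentage points lower from compound 2 to compound 3 (within the scatter) and also a number 6 percentage points lower from compound 1 to compound 3 (within the scatter). The change of chlorine placement from 3-chlorophenyl to 2-chlorophenyl thus joins the exchange of halogen, and the three halophenyl groups shown at this position are not separated by this read-out. No evidence bearing on these results is available. Still open, going by these compounds, is whether a phenyl carrying an amine or a carboxylic acid at this carbon would take the number in this assay beyond the scatter.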